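Swapping Methylsulfanyl for Dimethylamino on a Shared Core

This account rests on a few compounds, and the source may have more. Where it says the series, first, only, none or still open, it means among the compounds named here.

In a functional assay on the whole organism for inhibition, with Mus musculus as the target, at a dose of 1 mg/kg by the oral route (a higher number here means more inhibition at the dose given (going by the name of the read-out), a lower number less inhibition), two compounds have been measured so far:

Compound 1, `CCOc1cccc2c1c(O)c(C(=O)N(C)c1ccccc1)c(=O)n2C`, gives 40%.
Compound 2, `CSc1cccc2c1c(O)c(C(=O)N(C)c1ccccc1)c(=O)n2C`, gives 100%.

Going by the values given here, compound 2 therefore stands highest of the two numbers, and its only neighbour is compound 1. Among the compounds with values here, the single measured step, a number 60 percentage points higher from compound 1 to compound 2 (beyond the scatter), came with methylsulfanyl in place of ethoxy on an aromatic carbon.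

The next compound, compound 3, `CN(C)c1cccc2c1c(O)c(C(=O)N(C)c1ccccc1)c(=O)n2C`, differs from compound 2 in one place: dimethylamino in place of methylsulfanyl on an aromatic carbon. The measured step touched the same place but swapped a different pair of groups, so it does not directly bear on this change; it only shows that the number can move a great deal when the group at this place is altered. With no closer guide, the expected outcome is uncertain and a wide range is needed. Compound 3 is expected to give 70%, between 25% and 100%. This corresponds to an expected step of a number 30 percentage points lower from compound 2 to compound 3 (beyond the scatter), which may well fall within the scatter.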

Compound 3, a percentage reported as inhibition, in the whole organism at one dose (the size of the read-out at that dose, not a potency): 93%
For compound 3 the middle estimate is 23 percentage points below the measured one; the range from low to high includes it.
By their numbers in this assay, from the lowest: compound 1; then compounds 3 and 2 (each within the scatter of the next).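

In this assay, dimethylamino and methylsulfanyl on this aromatic carbon cannot be told apart, with a number 7 percentage points lower from compound 2 to compound 3 (within the scatter). Ethoxy now stands apart from both, with a number 53 percentage points higher from compound 1 to compound 3 (beyond the scatter), so the large rise seen earlier does not belong to methylsulfanyl alone: a nitrogen-linked group and a sulfur-linked group both give it. Nothing available explains why these two groups behave alike or why ethoxy differs from them.

Methoxy and ethylsulfanyl remain open: methoxy would show whether the low number goes with an oxygen-linked group in general, and ethylsulfanyl whether it goes with the longer chain. A single dose also leaves open whether compound 2 and compound 3 would separate at a lower dose.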